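The source may hold more compounds than are shown below. What is called first, only, known or untested is meant among the compounds shown, and "the series" means these compounds.

Compound 1 `CSCC[C@H](NC(=O)c1ccc(CNCc2c[nH]cn2)cc1-c1ccccc1C)C(=O)O` is known in a functional assay on NIH3T3 cells (Mus musculus) (a lower number here means that less compound is needed, a higher number that more compound is needed for the effect), only as a limit: compound 1 gives > 25 uM. Compound 2 `CSCC[C@H](NC(=O)c1ccc(CNCc2[nH]cnc2C)cc1-c1ccccc1C)C(=O)O` likewise ends at a limit, giving > 10 uM in this assay. The change from compound 1 to compound 2, a step that the two limits leave unreadable from compound 1 to compound 2, has no readable size because the limit of > 25 uM in this assay, at which 1 of the 2 values shown sits, and the limit of > 10 uM in this assay, at which 1 of the 2 values shown sits, bound both values. Compound 3 `CCOC(=O)[C@H](CCSC)NC(=O)c1ccc(CNCc2c[nH]cn2)cc1-c1ccccc1C` differs from compound 1 by ethyl in place of hydrogen on an oxygen next to a carbonyl group. Within the data shown here, no measured step bears on this change, so no step beyond the scatter is expected, which is a step that the limit leaves unreadable from compound 1 to compound 3. Compound 3 is therefore estimated at 40 uM in this assay, between 15 uM and 150 uM, with a limit again the likely outcome.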

Compound 3, concentration for half-maximal effect: 10 uM
Compound 3: middle estimate off by 4.0-fold (0.60 log units), on the high side, outside the stated range (below it).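

In this assay, among these compounds, the change from carboxy to ethoxycarbonyl gives an at least 2.5-fold lower number from compound 1 to compound 3 (0.39 log units; beyond the scatter) and is the first readable step here, since the step to compound 2 cannot be read. The position therefore responds to what sits on this oxygen. The true size may be larger, because compound 1 ends at a limit: the limit of > 25 uM in this assay, at which 1 of the 3 values shown sits.

Going by these compounds, what a methoxycarbonyl group or a carboxamide would give at this place remains open. On these data alone, it is also open whether ethoxycarbonyl would act the same way alongside the 4-methyl-1H-imidazol-5-yl group.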